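Aryl against allyl on the double-bonded nitrogen

The compounds below may be only part of what the source reports. "The series", "measured", "known", "first", "only" and "open" are said of these compounds alone.

Compound 3 `C=CC/N=C1\S/C(=C\c2ccc(OC)cc2)C(=O)N1C` carries an allyl group on a double-bonded nitrogen of the shared core. In a functional assay on HCT-116 cells (Homo sapiens) for antiproliferative activity, read by MTT assay, with a stated time of 72 h (a higher number here means a weaker inhibitor, a lower number a stronger inhibitor), compound 3 gives 79300 nM, the highest of the two numbers recorded for this series. The nearest is compound 1 `COc1ccc(/C=C2/CN(C)/C(=N/c3ccc(C(C)(C)C)cc3)S2)cc1`, which in this assay gives 25900 nM. Compound 2 `COc1ccc(/C=C2\S/C(=N\c3ccc(OC)cc3)N(C)C2=O)cc1` gives in this assay only a limit, > 100000 nM. Among the compounds with values here, the single step that bears on the present change is an at least 1.2-fold lower number from compound 2 to compound 3 (0.10 log units; that floor lies within the scatter), bounded by the limit of > 100000 nM in this assay, at which 1 of the 3 values shown sits, so its true size is not known. Compound 4 `COc1ccc(/C=C2\S/C(=N\c3ccc(C)cc3)N(C)C2=O)cc1` differs from compound 3 in one place: 4-methylphenyl in place of allyl on a double-bonded nitrogen. Because an at least 1.2-fold lower number from compound 2 to compound 3 (0.10 log units; that floor lies within the scatter) moved the number down when the aryl group was removed, putting an aryl group back is expected to move the number of compound 4 up again, with a real chance that only a limit is reported. The estimate for compound 4 in this assay is 110000 nM, within 40000 nM to 300000 nM. For compound 4 this estimate means an expected 1.4-fold higher number from compound 3 to compound 4 (0.14 log units; within the scatter).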

Compound 4, half-maximal inhibitory concentration: > 100000 nM
Compound 4: only a limit was reported; the forecaster's own chance of this, stated with the estimate: 45%; the middle value is on the limit's open side.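

In this assay compound 4 gives > 100000 nM, which is a limit and not a number. As far as these compounds go, putting 4-methylphenyl in place of allyl on the double-bonded nitrogen gives an at least 1.2-fold higher number from compound 3 to compound 4 (0.10 log units; that floor lies within the scatter), so a second aryl group now ends at a limit, and the true size of the step is unknown because the aryl compounds sit at that limit: the limit of > 100000 nM in this assay, at which 2 of the 4 values shown sit. The step for methyl in place of methoxy on an aromatic carbon cannot be read, so the 4-methylphenyl and 4-methoxyphenyl groups cannot be ranked against each other.

From the compounds shown here alone, how far compound 2 and compound 4 truly lie from compound 3 stays open. Also open, going by these compounds, is how a longer chain or an amine on the double-bonded nitrogen would read in this assay.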